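A few compounds are considered here, and "the series" means these few. Any claim that something is new, unique, unknown or untested is made for them only; others in the source may bear on it.

Measured so far in a functional assay on PC-9 cells (Homo sapiens) for inhibition, read by MTT assay, with a stated time of 48 h, tested at 10 uM; a lower number here means less inhibition, a higher number more inhibition at the concentration tested (going by the name of the read-out):
- compound 1 `COc1cc(NC(=O)Nc2cc(Nc3ccc(F)c(Cl)c3)ncn2)cc(OC)c1`: 77.5%
- compound 2 `COc1cc(NC(=O)Nc2cc(Nc3cc(F)ccc3OC)ncn2)cc(OC)c1`: 59.5%

Within the data shown here, compound 2 stands lowest of the two numbers; the one step between them, a number 18 percentage points lower from compound 1 to compound 2 (beyond the scatter), is modest and beyond the scatter, and it exchanges the whole aryl group on the nitrogen. Compound 3 `COc1cc(NC(=O)Nc2cc(Nc3cc(I)ccc3OC)ncn2)cc(OC)c1` differs from compound 2 by iodo in place of fluoro on an aromatic carbon, i.e. 5-fluoro-2-methoxyphenyl to 5-iodo-2-methoxyphenyl. Among the measured compounds shown here, no measured step bears directly on this change, so only a small step, if any beyond the scatter, is expected: a number 2.5 percentage points higher from compound 2 to compound 3 (within the scatter). Compound 3 is estimated at 62%, range 45% to 80%.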

Compound 3, a percentage reported as inhibition, at one concentration (the size of the read-out at that concentration, not a potency): 91%
Beside the measured number, compound 3's estimate is 29 percentage points below it; measured number above the stated range.
By their numbers in this assay, from the lowest: compound 2; then compound 1; then compound 3.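

The aromatic carbon para to a methoxy group is sensitive to its substituent: in this assay, iodo in place of fluoro gives a number 31.5 percentage points higher from compound 2 to compound 3 (beyond the scatter) as its step. The 2-methoxyphenyl pattern is therefore not inferior as such, since with iodo the exchange of the whole aryl group gives a number 13.5 percentage points higher from compound 1 to compound 3 (beyond the scatter) as its step, reversing the order seen with fluoro. No measured evidence bears on this gain. Open, going by these compounds, is whether chloro or bromo at this carbon would give intermediate numbers, and whether a nitrile or trifluoromethyl group could match iodo.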